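This account rests on a few compounds, and the source may have more. Where it says the series, first, only, none or still open, it means among the compounds named here.

Measured so far in an in vitro functional assay on 1321-N1 cells for agonist activity at P2Y purinoceptor 4 (Homo sapiens), read by scintillation proximity assay and inositol phosphate accumulation; a lower number here means that less compound is needed, a higher number that more compound is needed for the effect:

compound 1, `CNc1nc(=O)ccn1[C@@H]1O[C@H](COP(=O)(O)O)[C@@H](O)[C@H]1O` — > 100000 nM
compound 2, `CSc1nc(=O)ccn1[C@@H]1O[C@H](COP(=O)(O)O)[C@@H](O)[C@H]1O` — > 100000 nM

Both entries in this assay are limits of the assay rather than numbers. For compound 1 the value stands as a limit, > 100000 nM. For compound 2 the value is likewise a limit, > 100000 nM. Within the data shown here, the one step among the measured pair, a step that the two limits leave unreadable from compound 1 to compound 2, cannot be sized because both of its ends sit at the limit of > 100000 nM in this assay, at which 2 of the 2 values shown sit; whether methylsulfanyl in place of methylamino on the aromatic carbon moved anything is not readable. Compound 2 therefore stands at the limit of this assay, with no numbered value anywhere in the series.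

The next compound, compound 3, `CCCSc1nc(=O)ccn1[C@@H]1O[C@H](COP(=O)(O)O)[C@@H](O)[C@H]1O`, differs from compound 2 by ethyl in place of hydrogen on a saturated chain carbon bound to a sulfur. Among the measured compounds shown here, no measured step bears on this change; the only step on record is unreadable. Starting from a limit, with no readable movement in the series, the expectation is that compound 3 also reports a limit rather than a number in this assay. Compound 3 is estimated at 100000 nM, in the range 30000 nM to 300000 nM. The expected step from compound 2 is then a number no higher from compound 2 to compound 3 (the limit leaves the size open), effectively none beyond the scatter.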

Compound 3, half-maximal effective concentration: > 100000 nM
Compound 3: no number, only a limit (the forecaster's own chance of this, stated with the estimate: 75%); the middle value sits exactly at the limit.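

No new step can be read: the steps from compound 1 and from compound 2 to compound 3 cannot be sized, because each has a limit at both ends: the limit of > 100000 nM in this assay, at which 3 of the 3 values shown sit.

The compounds shown leave open whether propylsulfanyl in place of methylsulfanyl or methylamino changes anything in this assay, since none of the three has a numbered value.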